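The source may report more compounds than this note shows. Statements on the series, on what has been measured and on what is new or still open speak of the compounds shown alone.

Three compounds that share one core and differ only in the group on an amide-type nitrogen have been measured in an ADME assay on microsomes from liver (Mus musculus, strain CD-1) for metabolic stability, read by LC-MS, tested at 2 uM; a higher number here means that the compound lasts longer, a lower number that the compound disappears faster. Compound 1 `Cn1ccc2ccc(-c3cc(Nc4cnccc4C(=O)NCc4cncnc4)cc4nccnc34)cc21` gives 0.4 h, compound 2 `Cn1cc(NC(=O)c2ccncc2Nc2cc(-c3ccc4ccn(C)c4c3)c3nccnc3c2)cn1` gives 0.2 h, and compound 3 `CN1CCC(NC(=O)c2ccncc2Nc2cc(-c3ccc4ccn(C)c4c3)c3nccnc3c2)CC1=O` gives 0.717 h. Compound 3 therefore has the highest number of the three, but not clearly so: a 1.8-fold higher number from compound 1 to compound 3 (0.25 log units; within the scatter) lies within the scatter, whereas a 3.6-fold higher number from compound 2 to compound 3 (0.55 log units; beyond the scatter) lies beyond it and is modest.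

The next compound, compound 4 `CC(=O)N1CCCC(NC(=O)c2ccncc2Nc2cc(-c3ccc4ccn(C)c4c3)c3nccnc3c2)C1`, puts 1-acetylpiperidin-3-yl in place of 1-methyl-2-oxopiperidin-4-yl on that same nitrogen: 1-acetylpiperidin-3-yl in place of 1-methyl-2-oxopiperidin-4-yl on an amide-type nitrogen. Among the measured compounds shown here, no measured step makes this exact swap, so the guides are the swaps already seen at this place. Besides the two above, there is a 2.0-fold lower number from compound 1 to compound 2 (0.30 log units; within the scatter), also within the scatter. The largest of the three is only modest, and it is the one that starts from a different kind of group, 1-methyl-1H-pyrazol-4-yl. In this assay, no step beyond the scatter is therefore expected, and the estimated step is a 1.4-fold lower number from compound 3 to compound 4 (0.16 log units; within the scatter). For compound 4 the estimated half-life is 0.5 h, with an expected range from 0.2 h to 1.2 h.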

Compound 4, half-life: 0.4 h
Compound 4: the middle estimate sits 1.3-fold (0.10 log units) above what was measured; measured number inside the range.
By their numbers in this assay, from the lowest: compounds 2, 1, 4 and 3 (each within the scatter of the next, the first and the last beyond it).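

In this assay the 1-acetylpiperidin-3-yl group on the amide-type nitrogen cannot be told apart from any of the three earlier groups: the data show a 1.8-fold lower number from compound 3 to compound 4 (0.25 log units; within the scatter) and a 2.0-fold higher number from compound 2 to compound 4 (0.30 log units; within the scatter) and also no change at the digits printed from compound 1 to compound 4 (within the scatter). Among the compounds shown here, compound 4 therefore lies within the scatter of both compound 2 and compound 3, the only earlier pair set apart beyond it, and swapping 1-methyl-2-oxopiperidin-4-yl for 1-acetylpiperidin-3-yl, each with one six-membered non-aromatic ring and one hydrogen-bond acceptor, has no readable effect here. No measurement shown explains these numbers.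

On these data alone, whether the acetyl group or the ring attachment matters more remains open, and a comparison with 1-acetylpiperidin-4-yl would separate the two. Also open, as far as these compounds go, is whether a ring with a free amine, or an open chain such as 2-methoxyethyl, would move the half-life beyond the scatter.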